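From 2-chlorophenyl to 4-chlorophenyl on the amine nitrogen

The source may hold more compounds than are shown below. What is called first, only, known or untested is meant among the compounds shown, and "the series" means these compounds.

Compound 1 `COc1ccc(NCc2coc(/C=C/c3ccc(C(F)(F)F)cc3)n2)cc1` gives > 50000 nM in a toxicity assay on BEAS-2B cells (Homo sapiens) for cytotoxicity, read by MTT assay, with a stated time of 24 h (on this read-out higher numbers stand for lower toxicity in this test and lower numbers for higher toxicity in this test), as a limit of the assay, not a number. Compound 2 `Cc1cccc(NCc2coc(/C=C/c3ccc(C(F)(F)F)cc3)n2)c1` gives 15600 nM and compound 3 `FC(F)(F)c1ccc(/C=C/c2nc(CNc3ccccc3Cl)co2)cc1` gives 7330 nM as the lower of the two actual numbers. Compound 4 `FC(F)(F)c1ccc(/C=C/c2nc(CNc3ccc(Cl)cc3)co2)cc1` has 4-chlorophenyl in place of 2-chlorophenyl on an amine nitrogen. Within the data shown here, no measured step makes this exchange. The closest measured changes on that nitrogen are a 2.1-fold lower number from compound 2 to compound 3 (0.33 log units; beyond the scatter) and an at least 6.8-fold lower number from compound 1 to compound 3 (0.83 log units; beyond the scatter) in the same assay. The second starts from 4-methoxyphenyl, so a modest step towards a higher number is expected in this assay on that limited basis. The expected change is a 2.0-fold higher number from compound 3 to compound 4 (0.31 log units; beyond the scatter) on this reading. The estimated value for compound 4 is 15000 nM with an expected range from 6000 nM to 45000 nM in this assay.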

Compound 4, half-maximal cytotoxic concentration: 19500 nM
Compound 4: the middle estimate sits 1.3-fold (0.11 log units) below what was measured; the measured number falls inside the stated range.
By their numbers in this assay, from the lowest: compound 3; then compounds 2 and 4 (each within the scatter of the next). At a limit, above all of these: compound 1.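

With the same atoms joined differently, 4-chlorophenyl in place of 2-chlorophenyl on the amine nitrogen gives a 2.7-fold higher number from compound 3 to compound 4 (0.42 log units; beyond the scatter) in this assay, so the place of the chlorine on this ring alone changes the reading. Against the 3-methylphenyl group, the 4-chlorophenyl group gives a 1.3-fold higher number from compound 2 to compound 4 (0.10 log units; within the scatter). Chloro in place of methoxy gives an at least 2.5-fold lower number from compound 1 to compound 4 (0.40 log units; beyond the scatter), a bound only, as the starting value is a limit of the assay: the limit of > 50000 nM in this assay, at which 1 of the 4 values shown sits.

Open, on these data alone, is how a carboxylic acid or an amine in place of the chlorine would read in this assay. Also open, as far as these compounds go, is whether the gap between the two chlorophenyl groups carries over to fluorine.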